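A Methylsulfonyl Group Replaces Pyridin-4-yl on the Core

The source may report more compounds than this note shows. Statements on the series, on what has been measured and on what is new or still open speak of the compounds shown alone.

Measured so far, in an assay for inhibition of Fatty-acid amide hydrolase 1 (Rattus norvegicus); a higher number here means a weaker inhibitor, a lower number a stronger inhibitor:
- compound 1 `O=C(O)c1ccc(-c2cnc(C(=O)CCc3ccc(-c4ccccc4)cc3)o2)cn1` gives 44 nM
- compound 2 `O=C(CCc1ccc(-c2ccccc2)cc1)c1ncc(-c2ccncc2)o1` gives 2.3 nM
- compound 3 `CN(C)C(=O)c1cnc(C(=O)CCc2ccc(Oc3ccccc3)cc2)o1` gives 5.4 nM

Compound 2 stands lowest of the three numbers in this assay; compound 3 comes nearest and compound 1 lies furthest away. Compound 4 `CS(=O)(=O)c1cnc(C(=O)CCc2ccc(-c3ccccc3)cc2)o1` differs from compound 2 in one place: methylsulfonyl in place of pyridin-4-yl on an aromatic carbon.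

Among the compounds with values here, only one measured step touches this position on the core: a 19-fold lower number from compound 1 to compound 2 (1.28 log units; beyond the scatter), a large step, which shows that the group at this place matters a great deal. Within the data shown here, compound 3 carries a dimethylcarbamoyl group there, but also a different tail, so no single-change step exists; its number and that of compound 2 simply show that a small non-ring group at this place can sit close to pyridin-4-yl. On that basis a modest rise in the number is expected, a 3.5-fold higher number from compound 2 to compound 4 (0.54 log units; beyond the scatter), nothing like the step from the carboxylic acid. Compound 4 is therefore estimated at 8 nM in this assay, within a range of 2 nM to 30 nM.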

Compound 4, inhibition constant: 1.2 nM
Estimate against measurement, compound 4: 6.7-fold (0.82 log units) above; the measured number lies below the stated range.
By their numbers in this assay, from the lowest: compounds 4 and 2 (each within the scatter of the next); then compound 3; then compound 1.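

In this assay, the step to methylsulfonyl is a 1.9-fold lower number from compound 2 to compound 4 (0.28 log units; within the scatter), so pyridin-4-yl and methylsulfonyl cannot be told apart at this place on the core. Among these compounds, then, a ring is not needed on this aromatic carbon next to the ring oxygen: methylsulfonyl has no ring and fewer heavy atoms, yet it matches pyridin-4-yl. The large step of a 37-fold lower number from compound 1 to compound 4 (1.56 log units; beyond the scatter) shows that compound 1, with its 6-carboxypyridin-3-yl group, stands well apart from a non-ring group as well as from pyridin-4-yl.

As far as these compounds go, whether a simple amine, a methyl group or an unsubstituted phenyl ring would fit here as well remains open. Nothing shown gives a measured reason for any of these steps.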